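The source may hold more compounds than are shown below. What is called first, only, known or untested is meant among the compounds shown, and "the series" means these compounds.

Of the compounds shown here, three built on one shared core have been measured in an assay on isolated protein for inhibition of 2-Hydroxyacid oxidase 1 (Homo sapiens), with stated times of 30 min and 15 min; on this read-out lower numbers stand for stronger inhibition and higher numbers for weaker inhibition. Compound 1 `Cc1nc(-c2cccc(CN(C)c3ccc4[nH]nc(C(=O)O)c4c3)c2)sc1C` gives 290 nM, compound 2 `Cc1csc(-c2cccc(CN(C)c3ccc4[nH]nc(C(=O)O)c4c3)c2)n1` gives 650 nM and compound 3 `CN(C)c1noc(-c2cccc(CNc3ccc4[nH]nc(C(=O)O)c4c3)c2)n1` gives 170 nM, so compound 2 gives the highest number of the three. Within the data shown here, the step of a 2.2-fold higher number from compound 1 to compound 2 (0.35 log units; beyond the scatter) is the only measured step that bears on the change now considered, and it was modest. Compound 4 `CC(C)c1csc(-c2cccc(CN(C)c3ccc4[nH]nc(C(=O)O)c4c3)c2)n1` differs from compound 2 by isopropyl in place of methyl on an aromatic carbon. Among the measured compounds shown here, with only that one modest step to go on, the shift expected in this assay is a 1.4-fold lower number from compound 2 to compound 4 (0.16 log units; within the scatter), a change that may not reach beyond the scatter in either direction. For compound 4 the estimated value is 450 nM, with a range from 150 nM to 1400 nM.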

Compound 4, half-maximal inhibitory concentration: 710 nM
Compound 4: the middle estimate sits 1.6-fold (0.20 log units) below what was measured; low and high end bracket the measured number.
By their numbers in this assay, from the lowest: compounds 3 and 1 (each within the scatter of the next); then compounds 2 and 4 (each within the scatter of the next).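

On the aromatic carbon next to the ring nitrogen, this assay shows a 1.1-fold higher number from compound 2 to compound 4 (0.04 log units; within the scatter) for isopropyl in place of methyl, so the larger group leaves the number unchanged within the scatter. The result shows that this position tolerates isopropyl with no measurable loss or gain. Compared with the 4,5-dimethyl-1,3-thiazol-2-yl group of compound 1, the step is a 2.4-fold higher number from compound 1 to compound 4 (0.39 log units; beyond the scatter) and it stays modest.

As far as these compounds go, whether an amine or a carboxylic acid on this carbon would move the number remains open. Nothing available gives a reason for either step.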